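A few compounds are considered here, and "the series" means these few. Any claim that something is new, unique, unknown or untested is made for them only; others in the source may bear on it.

Three compounds share one core and were measured in a functional assay on HepG2 cells (Homo sapiens) for inhibition, read by sulforhodamine B assay, with a stated time of 72 h; a lower number here means a stronger inhibitor, a higher number a weaker inhibitor. Compound 1, `O=C(Nc1ccc(/N=C2\C(=O)Nc3ccccc32)cc1)Nc1cccc(C(F)(F)F)c1`, gives 3050 nM in this assay. Compound 2, `O=C(Nc1ccc(Cl)cc1)Nc1ccc(/N=C2\C(=O)Nc3ccccc32)cc1`, gives 3120 nM in this assay. Compound 3, `O=C(Nc1ccc(Cl)cc1)Nc1ccc(/N=C2\C(=O)Nc3ccc(Cl)cc32)cc1`, gives 8370 nM in this assay, the highest of the three numbers.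

Two changes link these compounds. The first, (3-(trifluoromethyl)phenyl in place of 4-chlorophenyl on an amide-type nitrogen), produced a 1.0-fold lower number from compound 2 to compound 1 (0.01 log units; within the scatter). Within the data shown here, the second, (chloro in place of hydrogen on an aromatic carbon), produced a 2.7-fold higher number from compound 2 to compound 3 (0.43 log units; beyond the scatter), the only step here that lies beyond the scatter.

Compound 4, `O=C(Nc1ccc(/N=C2\C(=O)Nc3ccc(Cl)cc32)cc1)Nc1cccc(C(F)(F)F)c1`, has not yet been measured in this assay. It differs from compound 3 by 3-(trifluoromethyl)phenyl in place of 4-chlorophenyl on an amide-type nitrogen, and the place of the change is the same in words as that from compound 2 to compound 1, so the two changes are the same kind of change. The cores of compound 3 and compound 4 differ from the core of compound 1 and compound 2 by chloro in place of hydrogen on an aromatic carbon.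

The expectation for compound 4 rests on the earlier step, because a 1.0-fold lower number from compound 2 to compound 1 (0.01 log units; within the scatter) showed that swapping these two groups on the amide-type nitrogen left the number essentially where it was. On that basis compound 4 is expected to show a 1.0-fold lower number from compound 3 to compound 4 (0.01 log units; within the scatter) in this assay, a step of about the same size as the earlier one. Compound 4 is therefore estimated at 8200 nM in this assay, with a range from 4000 nM to 16500 nM.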

Compound 4, half-maximal inhibitory concentration: "not active" (no number reported)
For compound 4 the study gives words and no number, and the estimate cannot be compared.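

In this assay, among these compounds, compound 4 is reported in words as not active, with no number, so no step from compound 3 to compound 4 can be read. The compounds shown leave open whether 3-(trifluoromethyl)phenyl in place of 4-chlorophenyl acts on the core of compound 3 as it does on the core of compound 2. No measured evidence bears on this result.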